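The compounds below may be only part of what the source reports. "The series", "measured", "known", "first", "only" and "open" are said of these compounds alone.

Measured compounds:
- compound 1, `Cc1cc(OC(=O)C(C)(C)CCC(CO[N+](=O)[O-])O[N+](=O)[O-])n(-c2ccccc2)n1`: 2500 nM
- compound 2, `CC(C)(CO[N+](=O)[O-])C(=O)O`: 13000 nM

In a functional assay on thoracic aorta (Rattus norvegicus, strain Wistar) for inhibition (a lower number here means that less compound is needed, a higher number that more compound is needed for the effect), compound 1 gives 2500 nM, the lowest of the two numbers recorded. In this assay compound 2 gives 13000 nM, a gap to compound 1 that lies beyond the scatter. Compound 3, `Cc1cc(OC(=O)C(C)(C)CCCCO[N+](=O)[O-])n(-c2ccccc2)n1`, has not yet been measured in this assay. It differs from compound 1 in one place: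

hydrogen in place of nitrooxy on a saturated chain carbon bound to two saturated chain carbons

Compound 3 thus keeps the core of compound 1 and its ester but carries one nitrooxy group where compound 1 carries two. Within the data shown here, no step between two measured compounds matches this change, so the expectation rests on the two values alone: compound 2, with a single nitrooxy group, shows a clearly higher number than compound 1. A moderate move towards a higher number is therefore expected, of the size a 2.4-fold higher number from compound 1 to compound 3 (0.38 log units; beyond the scatter). Compound 3 is estimated to give 6000 nM, within 2500 nM to 15000 nM.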

Compound 3, half-maximal effective concentration: 11000 nM
For compound 3 the middle estimate is 1.8-fold (0.26 log units) below the measured one, and the stated range covers the measured number.
By their numbers in this assay, from the lowest: compound 1; then compounds 3 and 2 (each within the scatter of the next).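

In this assay, among these compounds, hydrogen in place of nitrooxy on a saturated chain carbon bound to two saturated chain carbons gives a 4.4-fold higher number from compound 1 to compound 3 (0.64 log units; beyond the scatter) and so provides the first single-place comparison. With the core and ester unchanged, the 1,2-bis(nitrooxy)ethyl end of compound 1 needs less compound for the effect than the 2-(nitrooxy)ethyl end of compound 3, so the nitrooxy group at this position contributes to the lower number. Nothing shown accounts for the size of this step.

The compounds shown leave open whether a hydroxyl group, an amine or a carboxylic acid at this position would give a number closer to that of compound 1 or compound 3. They also leave open how a longer chain carrying the nitrooxy groups would change the number.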